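Carbamate replacement on the piperidine nitrogen of the series

The compounds below may be only part of what the source reports. "The series", "measured", "known", "first", "only" and "open" are said of these compounds alone.

Measured so far:
compound 1, `COC(=O)N1CCC(Oc2ncnc3c2CCN3c2ccc(S(C)(=O)=O)cc2F)CC1`, 316 nM
compound 2, `CS(=O)(=O)c1ccc(N2CCc3c(OC4CCN(C(=O)OCCF)CC4)ncnc32)c(F)c1`, 501 nM

Both compounds were tested in a functional assay on CHO-K1 cells for agonist activity at Glucose-dependent insulinotropic receptor (Homo sapiens), read by a luciferase reporter, with a stated time of 5 h; on this read-out higher numbers stand for an effect only at larger amounts of compound and lower numbers for an effect already at smaller amounts. Compound 2 gives the highest of the two numbers, with compound 1 as its nearest neighbour; the step of a 1.6-fold higher number from compound 1 to compound 2 (0.20 log units; within the scatter) lies within the scatter, so the two compounds cannot be ordered.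

Compound 3, `CS(=O)(=O)c1ccc(N2CCc3c(OC4CCN(C(=S)Sc5ccccc5)CC4)ncnc32)c(F)c1`, is not yet measured. It differs from compound 2 as follows: a group of 9 heavy atoms (7 carbon, 2 sulfur; one six-membered aromatic ring of carbon only) in place of a group of 6 heavy atoms (3 carbon, 2 oxygen, 1 fluorine; no ring), on an amine nitrogen in a ring.

Among the measured compounds shown here, only one measured step exists, and it concerns a small addition on the same ring nitrogen: a 1.6-fold higher number from compound 1 to compound 2 (0.20 log units; within the scatter). For the measured compounds named here, the change to compound 3 is far larger than that step, so the single step bears on it only loosely, and no measured pair shows what this new group does.

Going by the values given here, with no direct precedent, a moderate rise in the number is expected for compound 3, a 1.8-fold higher number from compound 2 to compound 3 (0.25 log units; within the scatter), with a wide range. The estimate for compound 3 is 900 nM, between 250 nM and 3500 nM.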

Compound 3, half-maximal effective concentration: 12.6 nM
For compound 3 the middle estimate is 71-fold (1.85 log units) above the measured one; measured number outside the range, below it.
By their numbers in this assay, from the lowest: compound 3; then compounds 1 and 2 (each within the scatter of the next).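

The position on the ring nitrogen can move this read-out strongly, which compound 1 and compound 2 alone did not show: their small groups stayed within the scatter of each other. The group entering in compound 3, with two sulfur atoms and a six-membered aromatic ring, gives a 40-fold lower number from compound 2 to compound 3 (1.60 log units; beyond the scatter) and a 25-fold lower number from compound 1 to compound 3 (1.40 log units; beyond the scatter), both large and beyond the scatter, so an effect appears at much smaller amounts of compound. No supporting data bear on the reason for this gain.

The sulfur atoms and the aromatic ring enter together, so the compounds shown cannot say which of them carries the step. A phenyl carbamate, keeping the ring with oxygen in place of sulfur, or a benzyl group on the same nitrogen would bear on that question.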